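The source may hold more compounds than are shown below. What is called first, only, known or untested is meant among the compounds shown, and "the series" means these compounds.

Compound 1 `COc1ccc(CCCc2ccc(OC)c(OC)c2)c(O)c1` gives 44.5% in an ADME assay on RAW264.7 cells (Mus musculus) for cytotoxicity, read by MTT assay, with a stated time of 24 h, tested at 10 ug/mL (on this read-out higher numbers stand for a weaker effect at the one concentration tested and lower numbers for a stronger effect), and compound 2 `COc1ccc(CCCc2ccc(OC)cc2O)cc1` gives 73.8%. Compound 1 thus stands lowest of the two numbers, separated from compound 2 by a number 29.3 percentage points higher from compound 1 to compound 2 (beyond the scatter). Compound 3 `COc1ccc(CCCc2ccc(OC)c(OC)c2OC)c(O)c1` differs from compound 1 by methoxy in place of hydrogen on an aromatic carbon. Within the data shown here, the only measured step runs the opposite way, hydrogen in place of methoxy, and reading it in reverse points to a lower number for the added methoxy. The expected step is therefore a number 6.5 percentage points lower from compound 1 to compound 3 (within the scatter), downward and modest. Compound 3 is estimated at 38%, with a range from 20% to 60%.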

Compound 3, a percentage reported as activity, at one concentration (the size of the read-out at that concentration, not a potency): 36.7%
Compound 3: the middle estimate sits 1.3 percentage points above what was measured; the range from low to high includes it.
By their numbers in this assay, from the lowest: compounds 3 and 1 (each within the scatter of the next); then compound 2.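

Methoxy in place of hydrogen at this position, ortho to a large group, ortho to a methoxy group and meta to a methoxy group, gives a number 7.8 percentage points lower from compound 1 to compound 3 (within the scatter) in this assay. The position therefore takes a methoxy group without a step beyond the scatter, whereas the earlier change gave a number 29.3 percentage points higher from compound 1 to compound 2 (beyond the scatter). One substituent at one position says little about the position in general.

As far as these compounds go, whether an amine or a carboxylic acid at this position would give a step beyond the scatter stays open. No measurement offered here explains these numbers.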